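Triazole-linked chromones: a benzyl substituent exchanged

The source may hold more compounds than are shown below. What is called first, only, known or untested is meant among the compounds shown, and "the series" means these compounds.

Compound 1 `O=c1ccoc2cc(OCc3cn(Cc4ccc([N+](=O)[O-])cc4)nn3)ccc12` reaches only the limit of the assay, > 100000 nM.
Compound 2 `N#Cc1cccc(Cn2cc(COc3ccc4c(=O)ccoc4c3)nn2)c1` gives 14300 nM.

For the measured compounds named here, in a functional assay on A549 cells (Homo sapiens) for cytotoxicity, read by MTT assay, with a stated time of 48 h (on this read-out higher numbers stand for weaker inhibition and lower numbers for stronger inhibition), compound 2 holds the only number among the two values shown; the other is a limit, (the limit of > 100000 nM in this assay, at which 1 of the 2 values shown sits). Going by the values given here, the single measured step, an at least 6.9-fold lower number from compound 1 to compound 2 (0.84 log units; beyond the scatter), concerns the same place as the change now considered. Compound 3 `COc1ccc(Cn2cc(COc3ccc4c(=O)ccoc4c3)nn2)cc1` differs from compound 2 by 4-methoxyphenyl in place of 3-cyanophenyl on a saturated chain carbon bound to an aromatic nitrogen. Among the compounds with values here, no measured step covers this particular exchange, and the one step available runs from a limit, so its size is known only as a bound. With the ring at that place already shown to move the number beyond the scatter in one direction, the step from compound 2 to compound 3 is expected to be a 1.7-fold higher number from compound 2 to compound 3 (0.24 log units; within the scatter), with a real chance of a limit. Compound 3 is therefore estimated at 25000 nM, in a range from 7000 nM to 100000 nM.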

Compound 3, half-maximal inhibitory concentration: 16500 nM
The estimate for compound 3 lay 1.5-fold (0.18 log units) above the measured number, within the range that was stated.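

In this assay, 4-methoxyphenyl in place of 3-cyanophenyl on a saturated chain carbon bound to an aromatic nitrogen gives a 1.2-fold higher number from compound 2 to compound 3 (0.06 log units; within the scatter), so this exchange leaves the number within the scatter. Methoxy in place of nitro on an aromatic carbon gives an at least 6.0-fold lower number from compound 1 to compound 3 (0.78 log units; beyond the scatter), which means that two different rings at this place now stand clear of 4-nitrophenyl, and the earlier step was not peculiar to 3-cyanophenyl. Compound 1 alone sits at a limit, so both steps from it are only bounds: the limit of > 100000 nM in this assay, at which 1 of the 3 values shown sits.

On these data alone, compounds 2 and 3 differ in both the group and its printed position on the ring, so what the position contributes on its own stays open. As far as these compounds go, it also remains open whether a plain benzyl group, or a ring bearing an amine or a carboxylic acid, would keep the number near those of compound 2 and compound 3.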